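Swapping the methyl of compound 1

This account rests on a few compounds, and the source may have more. Where it says the series, first, only, none or still open, it means among the compounds named here.

Values in a functional assay on HEK293 cells (Homo sapiens) for cytotoxicity (a higher number here means that more compound is tolerated, a lower number that less compound is tolerated), follow
- Compound 1 `COc1ccc([C@H]2CC(=O)N(c3cccc(C)c3)C2)cc1OC1CCCC1` gives > 10000 nM (a limit)
- Compound 2 `COc1ccc([C@H]2CC(=O)N(c3ccncc3)C2)cc1OC1CCCC1` gives > 10000 nM (a limit)
- Compound 3 `COc1ccc([C@H]2CC(=O)N(c3ccc([S+](C)[O-])cc3)C2)cc1OC1CCCC1` gives 7510 nM

Compound 1 stands at the limit of > 10000 nM in this assay, at which 2 of the 3 values shown sit, and so has no exact number. The change considered here is ((oxolan-3-yl)methyl)amino in place of methyl on an aromatic carbon and it leads to compound 4 `COc1ccc([C@H]2CC(=O)N(c3cccc(NCC4CCOC4)c3)C2)cc1OC1CCCC1` with ((oxolan-3-yl)methyl)amino in place of methyl on an aromatic carbon. For the measured compounds named here, two measured steps bear on it only loosely, since both exchange the whole group on the amide-type nitrogen. One is a step that the two limits leave unreadable from compound 1 to compound 2 and the other is an at least 1.3-fold lower number from compound 1 to compound 3 (0.12 log units; that floor lies within the scatter) so neither can be read as a step beyond the scatter. In this assay a small move toward lower numbers is therefore expected, an at least 1.1-fold lower number from compound 1 to compound 4 (0.04 log units; that floor lies within the scatter) and possibly none beyond the scatter. Compound 4 is estimated at 9000 nM with an expected range from 4000 nM to 20000 nM and may report only a limit.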

Compound 4, half-maximal cytotoxic concentration: > 10000 nM
Compound 4 ended at the assay's limit; the forecaster's own chance of this, stated with the estimate: 70%; middle value at least 1.1-fold (0.04 log units) from the limit.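

No step from compound 1 to compound 4 can be read in this assay, because both compounds stand at the same limit, not at a number: the limit of > 10000 nM in this assay, at which 3 of the 4 values shown sit.

The compounds shown leave open whether ((oxolan-3-yl)methyl)amino in place of methyl changes the number at all.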